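The source may hold more compounds than are shown below. What is called first, only, known or untested is meant among the compounds shown, and "the series" means these compounds.

Measured compounds:
Compound 1 `NC1CCC(Nc2nc(NCc3ccc(-c4ccccc4)cc3)c3ncn(C4CCCC4)c3n2)CC1`: 530 nM
Compound 2 `NC1CCC(Nc2nc(NCc3ccc(-c4ccco4)cc3)c3ncn(C4CCCC4)c3n2)CC1`: 96 nM

Both compounds were tested in a functional assay on K562 cells (Homo sapiens) for inhibition, with a stated time of 72 h; on this read-out higher numbers stand for weaker inhibition and lower numbers for stronger inhibition. On these two numbers compound 2 gives the lowest value, and its nearest neighbour, compound 1, is separated from it by a step that lies beyond the scatter: a 5.5-fold lower number from compound 1 to compound 2 (0.74 log units; beyond the scatter). Compound 3 `NC1CCC(Nc2nc(NCc3ccc(-c4ccccc4O)cc3)c3ncn(C4CCCC4)c3n2)CC1` has not yet been measured. It differs from compound 2 in one place: 2-hydroxyphenyl in place of furan-2-yl on an aromatic carbon. Within the data shown here, the only measured step that bears on this change is the one from compound 1 to compound 2, where a six-membered aromatic ring of carbon only gave way to furan-2-yl and the number fell modestly. Compound 3 brings back a six-membered aromatic ring of carbon only, now carrying a hydroxyl, so a move part of the way back toward compound 1 is expected, with the hydroxyl leaving the outcome open. Compound 3 is therefore estimated at 280 nM, within 100 nM to 800 nM, an expected step of a 2.9-fold higher number from compound 2 to compound 3 (0.46 log units; beyond the scatter).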

Compound 3, half-maximal inhibitory concentration: 2610 nM
Compound 3: middle estimate off by 9.3-fold (0.97 log units), on the low side; measured number above the stated range.
By their numbers in this assay, from the lowest: compound 2; then compound 1; then compound 3.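

In this assay, hydroxy on the phenyl ring gives a 4.9-fold higher number from compound 1 to compound 3 (0.69 log units; beyond the scatter), so this substitution weakens inhibition rather than being tolerated at this site, on an aromatic carbon para to a large group. The full change from furan-2-yl to 2-hydroxyphenyl gives a much larger loss, a 27-fold higher number from compound 2 to compound 3 (1.43 log units; beyond the scatter). Among these compounds, it combines two changes that the earlier compounds did not separate: the return to a six-membered aromatic ring of carbon only and the added hydroxy. Nothing shown accounts for the effect of the hydroxy.

As far as these compounds go, it remains open whether a methoxy or an amino group in place of the hydroxy would weaken inhibition to the same extent. The compounds also leave open whether a hydroxy elsewhere on the phenyl ring, or a thiophene in place of the furan, would follow the same trend.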